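Compound 2 to compound 3: dimethylamino for fluoro

The compounds below may be only part of what the source reports. "The series", "measured", "known", "first", "only" and "open" are said of these compounds alone.

In an ADME assay on Raji cells (Homo sapiens) for cytotoxicity, read by luminescence, with a stated time of 72 h (on this read-out lower numbers stand for an effect already at smaller amounts and higher numbers for an effect only at larger amounts of compound), compound 1 (`CCOC(=O)c1c(-c2cccc(-c3ccccc3)c2)[nH]c2cc(OC)ccc2c1=O`) gives > 21500 nM as a limit and not a number. Compound 2 (`CCOC(=O)c1c(-c2cccc(F)c2)[nH]c2cc(OC)ccc2c1=O`) gives > 21500 nM and this too is a limit, so its place in the series is known only as that limit. Within the data shown here, the whole series so far rests on the limit of > 21500 nM in this assay, at which 2 of the 2 values shown sit, and no number has yet been read.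

Compound 3 (`CCOC(=O)c1c(-c2cccc(N(C)C)c2)[nH]c2cc(OC)ccc2c1=O`) carries dimethylamino in place of fluoro on an aromatic carbon, meta to a large group, turning 3-fluorophenyl into 3-(dimethylamino)phenyl: dimethylamino in place of fluoro on an aromatic carbon.

Among the measured compounds shown here, the one measured step that bears on this is a step that the two limits leave unreadable from compound 1 to compound 2 on going from phenyl to fluoro at the same place. It offers no size to carry over, so no step beyond the scatter is expected in this assay and another reading at the limit is the likeliest result. Should a number appear, it would be expected on the lower side. The expected step reads a step that the limit leaves unreadable from compound 2 to compound 3 on this estimate. Estimated for compound 3 is 22000 nM with a range from 8000 nM to 40000 nM expected.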

Compound 3, half-maximal effective concentration: > 21500 nM
Compound 3 was reported as a limit; the forecaster's own chance of this, stated with the estimate: 75%; the middle value is on the limit's open side.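

In this assay compound 3 gives > 21500 nM, a limit and not a number. The steps joining compound 3 to compound 1 and to compound 2 therefore cannot be read. The compounds shown leave open whether any group at this place would give a readable number in this assay, as the series still rests on a single value: the limit of > 21500 nM in this assay, at which 3 of the 3 values shown sit.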